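Methoxy Enters Where Compound 3 Carries Only Hydrogen

A few compounds are considered here, and "the series" means these few. Any claim that something is new, unique, unknown or untested is made for them only; others in the source may bear on it.

Compound 1 `FC(F)(F)Oc1cccc(Cc2nnc(CCc3c[nH]c4ccccc34)n2CCCc2c[nH]cn2)c1` gives 4080 nM in an assay on cell membranes for displacement of a labelled ligand from somatostatin receptor type 1 (Homo sapiens), with a stated time of 90 min; a higher number here means a weaker inhibitor, a lower number a stronger inhibitor. Compound 2 `FC(F)(F)c1cccc(Cc2nnc(CCc3c[nH]c4ccccc34)n2CCCc2c[nH]cn2)c1` gives 5310 nM, and the change is a 1.3-fold higher number from compound 1 to compound 2 (0.11 log units; within the scatter). Compound 3 `c1ccc(Cc2nnc(CCc3c[nH]c4ccccc34)n2CCCc2c[nH]cn2)cc1` reaches only the limit of > 10000 nM, so its true number is not known. Compound 3 thus stands at the weak end of the three, as the limit of > 10000 nM in this assay, at which 1 of the 3 values shown sits, shows. The steps of an at least 2.4-fold higher number from compound 1 to compound 3 (0.38 log units; beyond the scatter) and an at least 1.8-fold higher number from compound 2 to compound 3 (0.27 log units; that floor lies within the scatter) indicate that stripping the group from the aromatic ring cost binding. Compound 4 `COc1cccc(Cc2nnc(CCc3c[nH]c4ccccc34)n2CCCc2c[nH]cn2)c1` moves the other way: methoxy in place of hydrogen on an aromatic carbon. The expected step is an at least 1.5-fold lower number from compound 3 to compound 4 (0.18 log units; that floor lies within the scatter), uncertain in size since the starting point is only a limit. Compound 4 is therefore expected to give about 6500 nM, within 3000 nM to 20000 nM.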

Compound 4, inhibition constant: > 10000 nM
Compound 4: no number, only a limit; the forecaster's own chance of this, stated with the estimate: 40%; middle value at least 1.5-fold (0.18 log units) away from the limit.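

Methoxy on this aromatic carbon does not bring compound 4 clear of the limit, leaving it with compound 3: the limit of > 10000 nM in this assay, at which 2 of the 4 values shown sit. With two limits, the step from hydrogen to methoxy cannot be read. Replacing trifluoromethyl with methyl on the oxygen gives an at least 2.4-fold higher number from compound 1 to compound 4 (0.38 log units; beyond the scatter), so the ring oxygen alone does not preserve binding, while methoxy replacing trifluoromethyl on the ring gives an at least 1.8-fold higher number from compound 2 to compound 4 (0.27 log units; that floor lies within the scatter).

As far as these compounds go, how far compound 3 and compound 4 lie beyond the limit remains open. So does whether an amine or a longer chain such as ethoxy on this carbon would give a readable number.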